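Chalcone Proliferation Assay: From Methoxyphenyl to Fluorophenyl

The compounds below may be only part of what the source reports. "The series", "measured", "known", "first", "only" and "open" are said of these compounds alone.

Compound 1 `COc1cccc(/C=C/C(=O)c2c(OC)cc(OC)cc2OC)c1` gives 31% in a functional assay on Caco-2 cells (Homo sapiens), read by fluorescence and BrdU incorporation, with a stated time of 48 h, tested at 10 uM; a lower number here means a stronger effect, a higher number a weaker effect of the compound at the concentration tested.
Compound 2 `COc1cc(O)c(C(=O)/C=C/c2ccccc2OC)c(OC)c1` gives 46% in this assay.

Going by the values given here, of the two numbers measured so far, compound 1 stands lowest; compound 2 is higher by a margin beyond the usual scatter. Compound 3 `COc1cc(OC)c(C(=O)/C=C/c2ccc(F)cc2)c(OC)c1` is not yet measured. It differs from compound 1 in one place: 4-fluorophenyl in place of 3-methoxyphenyl on a double-bonded chain carbon bound to a double-bonded chain carbon. Among the compounds with values here, no measured pair shows what this change does, so the expected step from compound 1 to compound 3 in this assay is small, in no sure direction, and probably within the scatter. Compound 3 is estimated at 35%, between 15% and 60%, an expected step of a number 4 percentage points higher from compound 1 to compound 3 (within the scatter).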

Compound 3, a percentage reported as activity, at one concentration (the size of the read-out at that concentration, not a potency): 39%
Estimate against measurement, compound 3: 4 percentage points below; low and high end bracket the measured number.
By their numbers in this assay, from the lowest: compounds 1, 3 and 2 (each within the scatter of the next, the first and the last beyond it).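

In this assay, placing 4-fluorophenyl in place of 3-methoxyphenyl on a double-bonded chain carbon bound to a double-bonded chain carbon gives a step of a number 8 percentage points higher from compound 1 to compound 3 (within the scatter). This first reading at this place shows that the read-out holds within the scatter when the one hydrogen-bond acceptor of the 3-methoxyphenyl group is gone. Nothing measured here accounts for this step.

The swap changes both the substituent and its number on the ring, and the compounds shown do not separate the two. Going by these compounds, what an amine or a carboxylic acid on this phenyl ring would do remains open.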